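Swapping carboxy for fluoro on a second triazine core

The compounds below may be only part of what the source reports. "The series", "measured", "known", "first", "only" and "open" are said of these compounds alone.

Of the compounds shown here, three of one family have been measured in an assay on cells for activation of Cystic fibrosis transmembrane conductance regulator (Homo sapiens), read by fluorescence, with stated times of 10 min and 12 s; a lower number here means that less compound is needed, a higher number that more compound is needed for the effect. Compound 1 `CCN(CC)c1nc(Nc2cccc(C(=O)O)c2)nc(OC(C(F)(F)F)C(F)(F)F)n1` gives 160 nM. Compound 2 `CCN(CC)c1nc(Nc2cccc(F)c2)nc(OC(C(F)(F)F)C(F)(F)F)n1` gives 140 nM. Compound 3 `CCN(CC)c1nc(Nc2cccc(C(=O)O)c2)nc(OCC(F)(F)C(F)F)n1` gives 500 nM.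

Compound 2 differs from compound 1 in one place: fluoro in place of carboxy on an aromatic carbon. That change produced a 1.1-fold lower number from compound 1 to compound 2 (0.06 log units; within the scatter). Compound 3 differs from compound 1 in its core: 2,2,3,3-tetrafluoropropyl in place of 2,2,2-trifluoro-1-(trifluoromethyl)ethyl on an oxygen on an aromatic ring. That change produced a 3.1-fold higher number from compound 1 to compound 3 (0.49 log units; beyond the scatter).

Compound 4 `CCN(CC)c1nc(Nc2cccc(F)c2)nc(OCC(F)(F)C(F)F)n1` has not yet been measured. It differs from compound 3 in the same way that compound 2 differs from compound 1: fluoro in place of carboxy on an aromatic carbon. The surroundings of the change are the same in both pairs, so this is the same change carried onto the core of compound 3.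

Compound 4 is expected to show a 1.1-fold lower number from compound 3 to compound 4 (0.05 log units; within the scatter), because a 1.1-fold lower number from compound 1 to compound 2 (0.06 log units; within the scatter) lay within the scatter and there is no sign that the core of compound 3 alters this. For compound 4 the expected result is 450 nM, with a range from 200 nM to 1000 nM.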

Compound 4, half-maximal effective concentration: 1600 nM
Compound 4: middle estimate off by 3.6-fold (0.55 log units), on the low side, and the stated range ends below it.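

In this assay, fluoro in place of carboxy did not carry over unchanged: with 2,2,3,3-tetrafluoropropyl on the oxygen it gave a 3.2-fold higher number from compound 3 to compound 4 (0.51 log units; beyond the scatter), and this differs from the step seen with the other chain: the same change on two cores in this assay, a 1.1-fold lower number (0.06 log units; within the scatter) from compound 1 to compound 2 and a 3.2-fold higher number (0.51 log units; beyond the scatter) from compound 3 to compound 4, 3.7-fold (0.56 log units) apart, beyond the scatter of two such steps. The change of chain, read the other way round, tells the same story: with fluoro on the ring it gave an 11-fold higher number from compound 2 to compound 4 (1.06 log units; beyond the scatter), which differs from the step seen with carboxy on the ring: the same change on two cores in this assay, a 3.1-fold higher number (0.49 log units; beyond the scatter) from compound 1 to compound 3 and an 11-fold higher number (1.06 log units; beyond the scatter) from compound 2 to compound 4, 3.7-fold (0.56 log units) apart, beyond the scatter of two such steps. So in these four compounds the effect of one change depends on which group stands at the other place, and a step measured on one core cannot simply be copied to the other, though the numbers do not show why this happens or how far it extends.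

Going by these compounds, it remains open whether the same dependence appears with other groups on the ring, such as a nitrile or an amide. On these data alone, it is equally open whether it appears with other chains on the oxygen, such as a plain propyl chain.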